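The source may report more compounds than this note shows. Statements on the series, on what has been measured and on what is new or still open speak of the compounds shown alone.

Measured so far in an ADME assay on a cell-free system (plasma, Rattus norvegicus) for protein binding; a lower number here means a smaller unbound share, a higher number a larger unbound share of the compound:
- compound 1, `Cc1nnc2sc(C(=O)NC3CN(c4ncc(C(F)(F)F)cn4)C3)c(N)c2c1C`: 0.028
- compound 2, `Cc1c(CF)nnc2sc(C(=O)NC3CN(c4ncc(C(F)(F)F)cn4)C3)c(N)c12`: 0.034

Among the compounds with values here, compound 1 stands lowest of these two numbers, though the only measured step, a 1.2-fold higher number from compound 1 to compound 2 (0.08 log units; within the scatter), is within the scatter, so the two compounds cannot be told apart on this assay. That step replaced a hydrogen on a saturated chain carbon bound to an aromatic carbon with fluoro.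

Compound 3, `Cc1c(Cl)nnc2sc(C(=O)NC3CN(c4ncc(C(F)(F)F)cn4)C3)c(N)c12`, has not yet been measured. It differs from compound 1 by chloro in place of methyl on an aromatic carbon. Within the data shown here, the one known step concerns a different change at a different place on the shared core, so it bears on this only loosely; it shows that a small one-atom swap on that ring left the unbound fraction essentially unchanged. A step in this assay of similar small size is therefore expected, if anything toward a slightly smaller unbound share, and not beyond the scatter. For compound 3 the unbound fraction in this assay is estimated at 0.025, with a likely range of 0.012 to 0.05, which means an expected step of a 1.1-fold lower number from compound 1 to compound 3 (0.05 log units; within the scatter).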

Compound 3, unbound fraction: 0.022
Compound 3: the middle estimate sits 1.1-fold (0.06 log units) above what was measured, within the range that was stated.
By their numbers in this assay, from the lowest: compounds 3, 1 and 2 (each within the scatter of the next).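

In this assay, chloro in place of methyl on this aromatic carbon next to the ring nitrogen gives a 1.3-fold lower number from compound 1 to compound 3 (0.10 log units; within the scatter) and so stays too small to read, and chloro in place of fluoromethyl at the same carbon gives a 1.5-fold lower number from compound 2 to compound 3 (0.19 log units; within the scatter) with the same outcome. This position has now carried methyl, fluoromethyl and chloro, the last a group with no carbon at all, and the unbound fraction of the three compounds cannot be told apart. Nothing measured here speaks to what lies behind this result.

From the compounds shown here alone, it remains open whether an amine, a carboxylic acid or a longer chain on this carbon would also stay within the scatter. Going by these compounds, it is equally open whether chloro would give the same reading elsewhere on the shared core.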